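The source may hold more compounds than are shown below. What is called first, only, known or untested is meant among the compounds shown, and "the series" means these compounds.

In an ADME assay on cells (Hepatocyte, Homo sapiens) for pharmacokinetics, read by LC-MS, with a stated time of 90 min, tested at 1 uM (a lower number here means slower removal, a higher number faster removal of the compound), compound 1 `C[C@@H](Nc1c(NCCCCCC(=O)NO)c(=O)c1=O)c1ccccc1` gives < 5 uL/min, which is a limit of the assay rather than a number. Compound 2 `C[C@H](Nc1c(NCCCCCC(=O)NO)c(=O)c1=O)c1ccccc1` likewise gives < 5 uL/min, again a limit. Within the data shown here, compound 3 `Cc1cccc(Nc2c(NCCCCCC(=O)NO)c(=O)c2=O)c1` gives 18 uL/min, the only number among the three values shown. The steps of an at least 3.6-fold higher number from compound 1 to compound 3 (0.55 log units; beyond the scatter) and an at least 3.6-fold higher number from compound 2 to compound 3 (0.55 log units; beyond the scatter) each put 3-methylphenyl in place of 1-phenylethyl, a different kind of change from the one now in view. Compound 4 `COc1ccc(Nc2c(NCCCCCC(=O)NO)c(=O)c2=O)cc1` differs from compound 3 by 4-methoxyphenyl in place of 3-methylphenyl on a nitrogen on an aromatic ring. Among the measured compounds shown here, no measured step covers an exchange of one aryl group for another, so for compound 4 no step beyond the scatter is expected: a 1.1-fold higher number from compound 3 to compound 4 (0.05 log units; within the scatter). Compound 4 is therefore estimated at 20 uL/min, within 8 uL/min to 50 uL/min.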

Compound 4, intrinsic clearance in a liver preparation (reported as CLH), per the amount of preparation that the assay uses: < 4.7 uL/min
Compound 4 gave a limit, no number; the forecaster's own chance of this, stated with the estimate: 15%; middle value at least 4.2-fold (0.62 log units) from the limit.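

this assay shows that the aryl group on this nitrogen matters: 4-methoxyphenyl in place of 3-methylphenyl gives an at least 3.8-fold lower number from compound 3 to compound 4 (0.58 log units; beyond the scatter), the first exchange of one aryl group for another seen here. Compound 4 gives < 4.7 uL/min, which is a limit of the assay and not a number. The steps from compound 1 and from compound 2 to compound 4 join limit to limit and cannot be read.

This change swaps both the group on the ring and its place there, and the compounds shown cannot separate the two. Open, from the compounds shown here alone, is how 3-methoxyphenyl or 4-methylphenyl on this nitrogen would read.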